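A few compounds are considered here, and "the series" means these few. Any claim that something is new, unique, unknown or untested is made for them only; others in the source may bear on it.

Measured compounds:
compound 1 `Cc1cc(Nc2cc(-c3ccccc3)[nH]n2)n2nc(SCC3CCCCC3)nc2n1` — > 50000 nM
compound 2 `CCCCCc1c(C)nc2nc(SCc3ccc(Cl)cc3)nn2c1Nc1cc(-c2ccccc2)[nH]n1` — > 50000 nM

In an ADME assay on GES1 cells (Homo sapiens) for inhibition, read by MTT assay, with a stated time of 72 h (a higher number here means a weaker inhibitor, a lower number a stronger inhibitor), compound 1 gives > 50000 nM, which is a limit of the assay and not a number. In this assay compound 2 gives > 50000 nM, likewise a limit rather than a measured number. Both of the known values therefore sit at the limit of > 50000 nM in this assay, at which 2 of the 2 values shown sit, so compound 1 stands nowhere in particular on the numbers shown: it is simply at the limit, and the other value is at the same limit. Among the measured compounds shown here, no step between two measured compounds is available.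

Compound 3 `Cc1cc(Nc2cc(-c3ccccc3)[nH]n2)n2nc(SCc3ccc(C(F)(F)F)cc3)nc2n1` has not yet been measured in this assay. It differs from compound 1 in one place: 4-(trifluoromethyl)phenyl in place of cyclohexyl on a saturated chain carbon bound to a sulfur. For the measured compounds named here, since every measured value here is a limit, there is no measured step on which to size this change. The step from compound 1 to compound 3 is expected to be a number no higher from compound 1 to compound 3 (the limit leaves the size open), that is, none beyond the scatter, with compound 3 expected to remain at the limit. Compound 3 is estimated at 50000 nM, in a range from 20000 nM to 100000 nM.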

Compound 3, half-maximal inhibitory concentration: 42700 nM
Compound 3: the middle estimate sits 1.2-fold (0.07 log units) above what was measured; measured number inside the range.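

In this assay compound 3 gives 42700 nM, the first value among the compounds shown that is a number and not a limit, with a 4-(trifluoromethyl)phenyl on a saturated chain carbon bound to a sulfur. The exchange of cyclohexyl for this group amounts to an at least 1.1-fold lower number from compound 1 to compound 3 (0.06 log units; that floor lies within the scatter); that figure is only a floor, so the change is not shown to exceed the scatter, and its true size stays unknown. Inhibition of these cells remains very weak across the set, and the other values are still limits: the limit of > 50000 nM in this assay, at which 2 of the 3 values shown sit.

The compounds shown leave open whether the aromatic ring or the trifluoromethyl group accounts for the number seen with compound 3, which a plain phenyl, a 4-chlorophenyl or a 4-methoxyphenyl at this place on the core of compound 1 could separate. They also leave open how an amine or a carboxylic acid on that ring, or a longer chain between the sulfur and the ring, would read in this assay.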